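The source may report more compounds than this note shows. Statements on the series, on what has been measured and on what is new or still open speak of the compounds shown alone.

Compound 1 `CC1CC/C(=N\Nc2ccc(F)cc2)c2ncc(C(=O)O)c(=O)n21`: > 1000 umol/kg
Compound 2 `CC1CC/C(=N\Nc2ccc(I)cc2)c2ncc(C(=O)O)c(=O)n21`: > 1000 umol/kg

In a functional assay on the whole organism for inhibition, with Rattus norvegicus as the target (on this read-out lower numbers stand for an effect already at smaller amounts and higher numbers for an effect only at larger amounts of compound), compound 1 reaches only a limit of the assay, > 1000 umol/kg. Compound 2 likewise reaches only a limit of the assay, > 1000 umol/kg. The step from compound 1 to compound 2 a step that the two limits leave unreadable from compound 1 to compound 2 is therefore unreadable, and compound 2 stands at the limit of > 1000 umol/kg in this assay, at which 2 of the 2 values shown sit. Compound 3 `Cc1cccc(N/N=C2\CCC(C)n3c2ncc(C(=O)O)c3=O)c1` has not been measured in this assay; it differs from compound 2 by 3-methylphenyl in place of 4-iodophenyl on an amine nitrogen.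

For the measured compounds named here, the only measured step bearing on this change, a step that the two limits leave unreadable from compound 1 to compound 2, gives no size, so no direction can be taken from the two measured compounds. Both sit at the limit, and nothing in the shown values suggests that a change at the same place leads out of it. The step from compound 2 to compound 3 is therefore expected to be a step that the limit leaves unreadable from compound 2 to compound 3, most likely again ending in a limit rather than a number. Compound 3 is estimated at 2000 umol/kg, with a range from 700 umol/kg to 6000 umol/kg.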

Compound 3, dose for 50% inhibition: 72.5 umol/kg
The estimate for compound 3 lay 28-fold (1.44 log units) above the measured number, and the stated range ends above it.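

In this assay, putting 3-methylphenyl on the amine nitrogen gives an at least 13-fold lower number from compound 2 to compound 3 (1.13 log units; beyond the scatter), and the same group measured against the 4-fluorophenyl of compound 1 gives an at least 13-fold lower number from compound 1 to compound 3 (1.13 log units; beyond the scatter). The group on this amine nitrogen can therefore move a compound off the limit of the assay, which the two earlier compounds could not show, and compound 3 is the only one of the three with a number rather than a limit: the limit of > 1000 umol/kg in this assay, at which 2 of the 3 values shown sit. The change is not a single one within the aromatic ring, however, since the halogen of 4-iodophenyl or 4-fluorophenyl gives way to a methyl group and the ring position of the substituent changes with it.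

The compounds shown leave open whether the lower number goes with the methyl group or with its place on the ring, a question that 4-methylphenyl and 3-iodophenyl would separate. Also open, on these data alone, is how far this position tolerates other groups, such as unsubstituted phenyl, 3-ethylphenyl or 3-methoxyphenyl, in this assay.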